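Methoxyphenyl regiochemistry on the shared core

This account rests on a few compounds, and the source may have more. Where it says the series, first, only, none or still open, it means among the compounds named here.

Among the measured compounds shown here, compound 2 `COc1cccc(-c2cn3cc(-c4ccccc4)nc3c(N)n2)c1` gives 21% in an assay on cells for displacement of a labelled ligand from transmembrane domain-containing protein TMIGD3 (Homo sapiens), read by scintillation counting, with a stated time of 120 min, tested at 1 uM (a higher number here means more inhibition at the concentration tested (going by the name of the read-out), a lower number less inhibition), the higher of the two numbers so far, with a gap to its nearest neighbour that is within the scatter. That neighbour, compound 1 `Nc1nc(Br)cn2cc(-c3ccccc3)nc12`, gives 14% in this assay. For the measured compounds named here, the one step measured, a number 7 percentage points higher from compound 1 to compound 2 (within the scatter), therefore says little about how any change at this position of the shared core is read by the assay. Compound 3 `COc1ccc(-c2cn3cc(-c4ccccc4)nc3c(N)n2)cc1` has the same atoms as compound 2, joined differently: 4-methoxyphenyl in place of 3-methoxyphenyl on an aromatic carbon. Going by the values given here, no measured step concerns the position of the methoxy group on the phenyl ring; the only step at this carbon exchanged bromo for 3-methoxyphenyl and stayed within the scatter. The expected step is accordingly a number 1 percentage points lower from compound 2 to compound 3 (within the scatter), no change beyond the scatter. For compound 3 the estimate in this assay is 20%, with a range from 8% to 34%.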

Compound 3, a percentage reported as inhibition, at one concentration (the size of the read-out at that concentration, not a potency): 23%
Beside the measured number, compound 3's estimate is 3 percentage points below it; measured number inside the range.
By their numbers in this assay, from the lowest: compounds 1, 2 and 3 (each within the scatter of the next).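

In this assay, moving the methoxy group from 3-methoxyphenyl to 4-methoxyphenyl gives a number 2 percentage points higher from compound 2 to compound 3 (within the scatter) and so does not register at the single concentration tested. The exchange of bromo for 4-methoxyphenyl, a number 9 percentage points higher from compound 1 to compound 3 (within the scatter), also stays inside the scatter, so at this aromatic carbon neither methoxyphenyl isomer separates from bromo. No evidence is available on what lies behind these readings.

Open, going by these compounds, is whether a different kind of group at this carbon, such as an amine, a carboxylic acid or a longer alkyl chain, would shift the number beyond the scatter. On these data alone, the phenyl and amino groups are the same in all three compounds, so what changes there would do remains open. These read-outs show only the size of the effect at the single concentration tested.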